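The source may report more compounds than this note shows. Statements on the series, on what has been measured and on what is new or still open speak of the compounds shown alone.

Compound 1, `CNC(=O)c1cc(Oc2ccc(NC(=O)c3cc(-c4ccc(F)cc4)ncn3)cc2F)ccn1`, and compound 2, `CNC(=O)c1cc(Oc2ccc(NC(=O)c3cc(-c4ccc(C)cc4)ncn3)cc2)ccn1`, share one core and are both examined in a functional assay on PC-3 cells (Homo sapiens) for cytotoxicity, read by MTT assay, with a stated time of 72 h; on this read-out lower numbers stand for stronger inhibition and higher numbers for weaker inhibition. For compound 1 the reading is a limit of the assay, > 100000 nM, not a number. For compound 2 the reading is likewise a limit, > 100000 nM, and not a number. Thus compound 2 stands at the edge of what this assay can report, and the limit of > 100000 nM in this assay, at which 2 of the 2 values shown sit, shows that both values given so far sit at that same limit, so no ordering between them can be drawn.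

Compound 3, `CNC(=O)c1cc(Oc2ccc(NC(=O)c3cc(-c4ccc(F)cc4)ncn3)cc2)ccn1`, has not yet been measured in this assay. It differs from compound 2 by fluoro in place of methyl on an aromatic carbon. Within the data shown here, no step between two measured compounds is available to show what fluoro in place of methyl on an aromatic carbon does here, so no direction can be read from the data; compound 1, which also carries the 4-fluorophenyl group, gives only a limit.

The step from compound 2 to compound 3 is expected to be small, a number no higher from compound 2 to compound 3 (the limit leaves the size open), with compound 3 estimated at 100000 nM, in a range from 30000 nM to 300000 nM, and most likely reported again only as a limit.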

Compound 3, half-maximal inhibitory concentration: > 100000 nM
Compound 3 ended at the assay's limit; the forecaster's own chance of this, stated with the estimate: 85%; the middle value lies on the limit itself.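

Compound 3 gives a limit and not a number, like compound 1 and compound 2, so neither the step from compound 2 nor the step from compound 1 can be read: the limit of > 100000 nM in this assay, at which 3 of the 3 values shown sit.

The three compounds leave open whether fluoro in place of methyl on an aromatic carbon, or hydrogen in place of fluoro, changes anything in this assay, where none of them yields a number.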